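Methoxy in Place of Chloro on a Benzyl Arm

The compounds below may be only part of what the source reports. "The series", "measured", "known", "first", "only" and "open" are said of these compounds alone.

The measured compounds and their values in a functional assay on CCRF-CEM cells (Homo sapiens) for inhibition, read by cell counting, with a stated time of 3 days; on this read-out higher numbers stand for weaker inhibition and lower numbers for stronger inhibition:
compound 1, `C=C(Br)C(=O)Nc1cccc(-c2cn3nc(Cc4ccc(Cl)cc4)sc3n2)c1`: 3300 nM
compound 2, `Nc1cccc(-c2cn3c(-c4ccccc4)csc3n2)c1`: 29000 nM
compound 3, `COc1ccc(-c2nn3cc(-c4cccc(N)c4)nc3s2)cc1`, a limit of the assay: >= 250000 nM

Compound 1 stands lowest of the two numbers in this assay. Its nearest neighbour, compound 2, sits at a higher number, and that gap lies beyond the usual scatter of the assay. Compound 3 gives no number at all in this assay, only a limit, (the limit of >= 250000 nM in this assay, at which 1 of the 3 values shown sits).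

The unmeasured compound 4, `C=C(Br)C(=O)Nc1cccc(-c2cn3nc(Cc4ccc(OC)cc4)sc3n2)c1`, differs from compound 1 in one place: methoxy in place of chloro on an aromatic carbon. For the measured compounds named here, the change is confined to a substituent on the outer ring, with the core and the acrylamide left untouched, and no pair of measured compounds shows the effect of this particular exchange.

With nothing measured to anchor it, the step from compound 1 to compound 4 is expected to be small, most likely within the scatter, with a slight lean toward a higher number: a 1.4-fold higher number from compound 1 to compound 4 (0.13 log units; within the scatter). Compound 4 is therefore estimated to give 4500 nM in this assay, within a range of 1500 nM to 14000 nM.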

Compound 4, half-maximal inhibitory concentration: 2300 nM
Compound 4: the middle estimate sits 2.0-fold (0.29 log units) above what was measured; the range from low to high includes it.
By their numbers in this assay, from the lowest: compounds 4 and 1 (each within the scatter of the next); then compound 2. At a limit, above all of these: compound 3.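

In this assay, for the compounds shown here, methoxy in place of chloro gives a 1.4-fold lower number from compound 1 to compound 4 (0.16 log units; within the scatter), the first comparison here between compounds that differ in one place. On this read-out, compound 1 and compound 4 cannot be told apart, so the 4-chlorobenzyl and 4-methoxybenzyl arms are interchangeable in this pair, even with the hydrogen-bond acceptor that methoxy brings and chloro lacks. Going by these compounds alone, nothing at hand explains why this exchange leaves the number within the scatter, as the only supporting information concerns the limit reached by compound 3 and has no bearing on this pair.

Still open, on these data alone, is whether an amine, a carboxylic acid or a longer chain at this place on the outer ring would also stay within the scatter of compound 1, since one exchange between chloro and methoxy says little about other groups. As far as these compounds go, what the acrylamide itself contributes also stays open: compound 2 and compound 3 differ from compound 1 and compound 4 in more than one place, so neither gives a clean reading of that group.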